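The source may report more compounds than this note shows. Statements on the series, on what has been measured and on what is new or still open speak of the compounds shown alone.

Compound 1 `COC(=O)c1cc(OCC(=O)[C@H](CC(=O)O)NC(=O)[C@@H](NC(=O)COc2cccc3ccccc23)C(C)C)no1` is the anchor of this small set. For the measured compounds named here, in a functional assay on Jurkat cells (Homo sapiens) for inhibition (on this read-out higher numbers stand for weaker inhibition and lower numbers for stronger inhibition), compound 1 gives 71000 nM, the only outright number among the three measured values. Compound 2 `CC(C)[C@H](NC(=O)COc1cccc2ccccc12)C(=O)N[C@@H](CC(=O)O)C(=O)CSc1nnnn1C` gives in this assay only the limit > 200000 nM. Compound 3 `CC(C)[C@H](NC(=O)COc1cccc2ccccc12)C(=O)N[C@@H](CC(=O)O)C(=O)CSc1nc2ccccc2[nH]1` likewise reaches in this assay only the limit > 200000 nM. Compound 4 `CC(C)[C@H](NC(=O)COc1cccc2ccccc12)C(=O)N[C@@H](CC(=O)O)C(=O)CSc1nc2ccccc2s1` has not yet been measured. It differs from compound 1 by (1,3-benzothiazol-2-yl)sulfanyl in place of (5-(methoxycarbonyl)-1,2-oxazol-3-yl)oxy on a saturated chain carbon bound to a carbonyl carbon. Two measured steps resemble this change closely: an at least 2.8-fold higher number from compound 1 to compound 2 (0.44 log units; beyond the scatter) and an at least 2.8-fold higher number from compound 1 to compound 3 (0.44 log units; beyond the scatter), each also replacing the (5-(methoxycarbonyl)-1,2-oxazol-3-yl)oxy group with a group bound through a sulfur at the same saturated chain carbon, and each ending at the limit of > 200000 nM in this assay, at which 2 of the 3 values shown sit. The step from compound 2 to compound 3 cannot be read, since both values are limits. The change to compound 4 is of the same kind, so a weakening of at least modest size is expected, a 3.5-fold higher number from compound 1 to compound 4 (0.55 log units; beyond the scatter). Compound 4 is therefore estimated at 250000 nM in this assay, within 100000 nM to 800000 nM, and most likely reported only as a limit.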

Compound 4, half-maximal inhibitory concentration: > 200000 nM
Compound 4 gave a limit, no number; the forecaster's own chance of this, stated with the estimate: 70%; the middle value lies beyond the limit too.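

Putting (1,3-benzothiazol-2-yl)sulfanyl in place of (5-(methoxycarbonyl)-1,2-oxazol-3-yl)oxy on this saturated chain carbon gives an at least 2.8-fold higher number from compound 1 to compound 4 (0.44 log units; beyond the scatter), so a third sulfur-linked group also weakens inhibition. The leaving and entering groups have the same heavy-atom count, so here the weakening comes without any change in that count. Compound 4 gives only a limit, and the steps among compound 2, compound 3 and compound 4 cannot be read, so these sulfur-linked groups cannot be ranked in this assay: the limit of > 200000 nM in this assay, at which 3 of the 4 values shown sit.

Compound 1 differs from compound 4 in both the linking atom and the ring system attached to it, so the compounds shown do not separate these two changes. A (1,3-benzothiazol-2-yl)oxy group or a (5-(methoxycarbonyl)-1,2-oxazol-3-yl)sulfanyl group at the same place would begin to pull them apart.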